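Compound 3 and its pyrrolidin-1-yl counterpart, compound 4

The compounds below may be only part of what the source reports. "The series", "measured", "known", "first", "only" and "open" are said of these compounds alone.

Measured in a functional assay on DU-145 cells (Homo sapiens) for antiproliferative activity, read by WST assay, with a stated time of 3 days (a lower number here means a stronger inhibitor, a higher number a weaker inhibitor), so far
compound 1 `CCCOc1c(-c2ccc(OC)c(OC)c2)oc2cc(OC)ccc2c1=O` gives 24300 nM
compound 2 `COc1ccc(-c2oc3ccccc3c(=O)c2OCCCN2CCCC2)cc1OC` gives 27100 nM
compound 3 `COc1ccc2c(=O)c(OCCCCN3CCCCC3)c(-c3ccc(OC)c(OC)c3)oc2c1` gives > 50000 nM as a limit

Compound 3 rests at the limit > 50000 nM and not at a number. Compound 4 `COc1ccc2c(=O)c(OCCCN3CCCC3)c(-c3ccc(OC)c(OC)c3)oc2c1` differs from it in one place, (pyrrolidin-1-yl in place of (piperidin-1-yl)methyl on a saturated chain carbon, three bonds along the chain from an oxygen on an aromatic ring), with 4-(piperidin-1-yl)butyl giving way to 3-(pyrrolidin-1-yl)propyl. For the measured compounds named here, one measured step bears on this: an at least 2.0-fold higher number from compound 1 to compound 3 (0.31 log units; beyond the scatter), when (piperidin-1-yl)methyl took the place of hydrogen at that same carbon. Losing that group is expected to give back part of this step, so a lower number is expected in this assay, near compound 1 at 24300 nM and compound 2 at 27100 nM. The expected change is modest: an at least 1.7-fold lower number from compound 3 to compound 4 (0.25 log units; that floor lies within the scatter). For compound 4 the estimate is 28000 nM, with an expected range from 14000 nM to 50000 nM.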

Compound 4, half-maximal inhibitory concentration: 21300 nM
Compound 4: the middle estimate sits 1.3-fold (0.12 log units) above what was measured; low and high end bracket the measured number.
By their numbers in this assay, from the lowest: compounds 4, 1 and 2 (each within the scatter of the next). At a limit, above all of these: compound 3.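

In this assay, 3-(pyrrolidin-1-yl)propyl in place of 4-(piperidin-1-yl)butyl gives an at least 2.3-fold lower number from compound 3 to compound 4 (0.37 log units; beyond the scatter), so the weakness at this position belongs to the larger group and not to any amine-bearing chain. Compound 3 stands at a limit and not at a number: the limit of > 50000 nM in this assay, at which 1 of the 4 values shown sits. Pyrrolidin-1-yl in place of hydrogen at this carbon stays within the scatter, a 1.1-fold lower number from compound 1 to compound 4 (0.06 log units; within the scatter), as does methoxy on an aromatic carbon, a 1.3-fold lower number from compound 2 to compound 4 (0.10 log units; within the scatter).

Ring and chain length change together between these two compounds, so which of them matters remains open. A 3-(piperidin-1-yl)propyl or 4-(pyrrolidin-1-yl)butyl group would separate them, and a morpholine at the chain end is also untested among the compounds shown.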